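Thiophen-3-yl in place of 1H-pyrrol-2-yl

The source may hold more compounds than are shown below. What is called first, only, known or untested is meant among the compounds shown, and "the series" means these compounds.

In a functional assay on HCT-116 cells (Homo sapiens), read by sulforhodamine B assay, with a stated time of 5 days (a lower number here means a stronger inhibitor of growth, a higher number a weaker inhibitor of growth), compound 1 `OC[C@H]1O[C@@H](n2cc(F)c3c(-c4ccccc4)ncnc32)[C@H](O)[C@@H]1O`, which carries phenyl, gives > 10000 nM, a limit of the assay and not a number. Among the compounds with values here, with 1H-pyrrol-2-yl at the same place on the shared core, compound 2 `OC[C@H]1O[C@@H](n2cc(F)c3c(-c4ccc[nH]4)ncnc32)[C@H](O)[C@@H]1O` gives 450 nM, the only true number so far. Within the data shown here, the one measured step, an at least 22-fold lower number from compound 1 to compound 2 (1.34 log units; beyond the scatter), is large, and its size rests on (the limit of > 10000 nM in this assay, at which 1 of the 2 values shown sits). It shows that the group at this place can matter greatly in this assay, but it does not test a thiophene.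

Compound 3 `OC[C@H]1O[C@@H](n2cc(F)c3c(-c4ccsc4)ncnc32)[C@H](O)[C@@H]1O` has thiophen-3-yl in place of 1H-pyrrol-2-yl on an aromatic carbon. The entering group keeps the five-membered aromatic ring with 1 hetero atom, so the whole loss seen between compound 2 at 450 nM and the phenyl of compound 1 is not expected to return. The expected change is a 1.3-fold higher number from compound 2 to compound 3 (0.12 log units; within the scatter), which is estimated to stay within the scatter, though the range leans towards weaker inhibition. For compound 3 the estimated value is 600 nM. The expected range for compound 3 runs from 120 nM to 4000 nM.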

Compound 3, concentration for 50% growth inhibition: 140 nM
Estimate against measurement, compound 3: 4.3-fold (0.63 log units) above, and the stated range covers the measured number.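

In this assay, thiophen-3-yl in place of 1H-pyrrol-2-yl gives a 3.2-fold lower number from compound 2 to compound 3 (0.51 log units; beyond the scatter), so the hydrogen-bond donor counted on 1H-pyrrol-2-yl is not required for growth inhibition in this series: the entering group counts none, and the number still falls. Against the phenyl of compound 1, the same group gives an at least 71-fold lower number from compound 1 to compound 3 (1.85 log units; beyond the scatter), and both compounds with a five-membered aromatic ring with 1 hetero atom at this place now lie far from the phenyl compound, with none of the compounds shown going against that pattern. Compound 1 stands at a limit of the assay and not at a number, so the size of that step is only a bound: the limit of > 10000 nM in this assay, at which 1 of the 3 values shown sits.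

The compounds shown do not separate the exchange of nitrogen for sulfur from the change in how the ring is attached, a question that thiophen-2-yl or 1H-pyrrol-3-yl would address. They also leave open whether a pyridinyl ring, or an amine or a methoxy group with no ring at all, would be tolerated at this place on the shared core.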